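The source may report more compounds than this note shows. Statements on the series, on what has been measured and on what is new or still open speak of the compounds shown alone.

Compounds measured in a functional assay on HEK293 cells for negative allosteric modulation of metabotropic glutamate receptor 5 (Rattus norvegicus), read by FLIPR and calcium flux, with a stated time of 170 s; on this read-out higher numbers stand for weaker inhibition and lower numbers for stronger inhibition:
compound 1 `N#Cc1ccc(NC(=O)c2cc3n(n2)CCCC3)nc1`, 90 nM
compound 2 `Cc1cccc(NC(=O)c2cc3n(n2)CCCC3)n1`, "not active" (no number reported)

Among the measured compounds shown here, compound 2 thus carries no number in this assay and stands only as inactive, while compound 1 gives the single measured value of the set. Compound 3 `O=C(Nc1cccc(C(F)(F)F)n1)c1cc2n(n1)CCCC2` differs from compound 2 in one place: trifluoromethyl in place of methyl on an aromatic carbon. For the measured compounds named here, no step between measured compounds covers this change, so its size is unknown; a shift of any size in either direction, or none beyond the scatter, remains possible. Compound 3 is expected at 2000 nM in this assay, within an estimated range of 300 nM to 20000 nM, and a limit instead of a number is a real possibility.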

Compound 3, half-maximal inhibitory concentration: "not active" (no number reported)
Compound 3 has no reported number here; the estimate stays without a comparison.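

Compound 2 and compound 3 both stand without a number, so no step can be read between them. From the compounds shown here alone, whether trifluoromethyl in place of methyl changes inhibition at all stays open. No supporting measurement bears on this result.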